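Changing the amide substituent in a three-compound series

This account rests on a few compounds, and the source may have more. Where it says the series, first, only, none or still open, it means among the compounds named here.

Compound 1 `COc1ccc2c(=O)c(/C=C/C(=O)NCc3cccc(F)c3)coc2c1` gives 17600 nM in a functional assay on HeLa cells (Homo sapiens) for inhibition, read by MTT assay, with a stated time of 48 h; on this read-out lower numbers stand for stronger inhibition and higher numbers for weaker inhibition. Compound 2 `CCOc1ccc(NC(=O)/C=C/c2coc3cc(OC)ccc3c2=O)cc1` in this assay reaches only the assay's limit, > 100000 nM. Compound 3 `COc1ccc(NC(=O)/C=C/c2coc3cc(OC)ccc3c2=O)cc1` gives 13000 nM in this assay.

Of the two plain numbers, compound 3 holds the lower, though the difference from compound 1 is within the scatter a 1.4-fold lower number from compound 1 to compound 3 (0.13 log units; within the scatter). Compound 4 `COc1ccc2c(=O)c(/C=C/C(=O)Nc3cccc(C)c3)coc2c1` differs from compound 3 by 3-methylphenyl in place of 4-methoxyphenyl on an amide-type nitrogen. For the measured compounds named here, no measured step exchanges one ring substituent for another in this way; the measured steps show that the group on the amide-type nitrogen can leave the number nearly unchanged a 1.4-fold lower number from compound 1 to compound 3 (0.13 log units; within the scatter) or carry it to the limit an at least 5.6-fold higher number from compound 1 to compound 2 (0.75 log units; beyond the scatter) and back an at least 7.6-fold lower number from compound 2 to compound 3 (0.88 log units; beyond the scatter). Compound 4 is therefore expected to give about 20000 nM, between 7000 nM and 60000 nM. The step expected from this estimate is a 1.5-fold higher number from compound 3 to compound 4 (0.19 log units; within the scatter).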

Compound 4, half-maximal inhibitory concentration: > 100000 nM
Compound 4 was reported as a limit; the forecaster's own chance of this, stated with the estimate: 15%; middle value at least 5.0-fold (0.69 log units) from the limit.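

The change from 4-methoxyphenyl to 3-methylphenyl on the amide-type nitrogen is enough to give an at least 7.6-fold higher number from compound 3 to compound 4 (0.88 log units; beyond the scatter), so a phenyl ring on this nitrogen does not by itself keep a measurable number. Compound 4 also compares poorly with the benzyl-bearing compound, with an at least 5.6-fold higher number from compound 1 to compound 4 (0.75 log units; beyond the scatter). Compound 2 keeps an ether oxygen and compound 4 has none, yet the step between them cannot be read, as both are limits: the limit of > 100000 nM in this assay, at which 2 of the 4 values shown sit.

The 3-methylphenyl group differs from 4-methoxyphenyl in both its substituent and that substituent's place on the ring, so the two effects remain tangled. A 4-methylphenyl or 3-methoxyphenyl group would separate them.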